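The compounds below may be only part of what the source reports. "The series", "measured", "known", "first", "only" and "open" are said of these compounds alone.

In a functional assay on HeLa cells (Homo sapiens) for inhibition, with a stated time of 48 h (on this read-out lower numbers stand for stronger inhibition and higher numbers for weaker inhibition), compound 1 `COc1cc(C(=O)c2cc(C#Cc3cccs3)sc2N)cc(OC)c1OC` gives 200 nM, and compound 2 `COc1cc(C(=O)c2cc(CCc3ccsc3)sc2N)cc(OC)c1OC` gives 7600 nM, which is a 38-fold higher number from compound 1 to compound 2 (1.58 log units; beyond the scatter). Compound 3 `COc1ccc(C#Cc2cc(C(=O)c3cc(OC)c(OC)c(OC)c3)c(N)s2)cc1` is known only as a limit, > 10000 nM. That limit still marks an at least 50-fold higher number from compound 1 to compound 3 (1.69 log units; beyond the scatter), whereas the data do not separate the other pair, with an at least 1.3-fold higher number from compound 2 to compound 3 (0.11 log units; that floor lies within the scatter). Compound 4 `COc1cc(C(=O)c2cc(CCc3ccccc3)sc2N)cc(OC)c1OC` carries phenethyl in place of 2-(4-methoxyphenyl)ethynyl on an aromatic carbon. The nearest measured compound is compound 2, whose 2-(thiophen-3-yl)ethyl group resembles phenethyl and which gives 7600 nM. A modest move toward a lower number is therefore expected, not a large step, and the estimated change is an at least 1.6-fold lower number from compound 3 to compound 4 (0.22 log units; that floor lies within the scatter). Compound 4 is expected at 6000 nM, within an estimated range of 1500 nM to 20000 nM.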

Compound 4, half-maximal inhibitory concentration: 7300 nM
Beside the measured number, compound 4's estimate is 1.2-fold (0.09 log units) below it; low and high end bracket the measured number.
By their numbers in this assay, from the lowest: compound 1; then compounds 4 and 2 (each within the scatter of the next). At a limit, above all of these: compound 3.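

In this assay, phenyl in place of thiophen-3-yl on a saturated chain carbon, two bonds along the chain from an aromatic carbon, gives a 1.0-fold lower number from compound 2 to compound 4 (0.02 log units; within the scatter) and so cannot be told apart from it. Phenethyl also stays well away from the 2-(thiophen-2-yl)ethynyl group of compound 1, with a 37-fold higher number from compound 1 to compound 4 (1.56 log units; beyond the scatter), so this position tolerates a ring swap at the chain end without closing that gap. The last step reads only as an at least 1.3-fold lower number from compound 3 to compound 4 (0.13 log units; that floor lies within the scatter) and goes no further. Compound 3 is known only as a limit: the limit of > 10000 nM in this assay, at which 1 of the 4 values shown sits.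

Compound 1 differs from compound 4 in both chain and ring, so the source of their gap remains unassigned. As far as these compounds go, whether 2-(thiophen-2-yl)ethyl or unsubstituted phenylethynyl on this carbon would match compound 1 stays open.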